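Moving the amine around the phenyl ring of compound 2

This account rests on a few compounds, and the source may have more. Where it says the series, first, only, none or still open, it means among the compounds named here.

Measured compounds:
compound 1, `CC(=O)Nc1cccc(-c2cnc3[nH]cc(-c4ccncc4)c3c2)c1`: 34.3 nM
compound 2, `Nc1cccc(-c2cnc3[nH]cc(-c4ccncc4)c3c2)c1`: 42.7 nM

The two measured compounds share one core and differ only at the phenyl ring hanging from it. In an assay on isolated protein for inhibition of high affinity nerve growth factor receptor (Homo sapiens), read by 33P incorporation (on this read-out lower numbers stand for stronger inhibition and higher numbers for weaker inhibition), compound 1 gives 34.3 nM and compound 2 gives 42.7 nM. Among the compounds with values here, the one recorded step, a 1.2-fold higher number from compound 1 to compound 2 (0.10 log units; within the scatter), is hydrogen in place of acetyl on a nitrogen on an aromatic ring and lies within the scatter. Compound 2 therefore shows the higher of the two numbers, but the two cannot be told apart on this evidence.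

Compound 3, `Nc1ccc(-c2cnc3[nH]cc(-c4ccncc4)c3c2)cc1`, has not been measured. It differs from compound 2 by 4-aminophenyl in place of 3-aminophenyl on an aromatic carbon. Within the data shown here, no measured step changes where the amine sits on that ring, so the recorded step says nothing directly about this move; it only shows that trimming the amine itself changed little. A step of modest size in either direction is expected in this assay, and the range must stay wide. Compound 3 is estimated at 55 nM, between 15 nM and 200 nM, which would mean a step of a 1.3-fold higher number from compound 2 to compound 3 (0.11 log units; within the scatter).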

Compound 3, half-maximal inhibitory concentration: 25 nM
Compound 3: the middle estimate sits 2.2-fold (0.34 log units) above what was measured; the measured number falls inside the stated range.
By their numbers in this assay, from the lowest: compounds 3, 1 and 2 (each within the scatter of the next).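

Putting 4-aminophenyl in place of 3-aminophenyl on this aromatic carbon of the shared core gives a 1.7-fold lower number from compound 2 to compound 3 (0.23 log units; within the scatter) in this assay, so compound 2 and compound 3 cannot be told apart. The earlier step changed only what sits on the nitrogen, whereas this one changes where the amine sits on the phenyl ring, with the same atoms joined differently, and neither of these two placements stands out from the other on this evidence. Nothing measured in this set bears on why the two placements read alike.

From the compounds shown here alone, whether an acetyl on the nitrogen of compound 3 would again leave the number within the scatter, as it does for the pair of compound 1 and compound 2, remains open. Going by these compounds, it is also open whether a hydroxyl or a carboxylic acid in place of the amine on the phenyl ring would give numbers close to these, or whether the amine matters at this position at all.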